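The compounds below may be only part of what the source reports. "The series", "measured", "known", "first", "only" and "open" are said of these compounds alone.

Measured in a functional assay on SK-OV-3 cells (Homo sapiens) for antiproliferative activity, read by MTT assay, with a stated time of 24 h; a higher number here means a weaker inhibitor, a lower number a stronger inhibitor:
- Compound 1 `COc1cccc(/C=C/C(=O)c2ccc(OC)c3c2OC(C)(C)C=C3)c1`: 9360 nM
- Compound 2 `COc1ccc(C(=O)/C=C/c2ccccc2)c2c1C=CC(C)(C)O2`: > 10000 nM (a limit of the assay, not a number)
- Compound 3 `COc1ccc(C(=O)/C=C/c2ccccn2)c2c1C=CC(C)(C)O2`: 8390 nM

Compound 3, at 8390 nM, lies within the scatter of compound 1, at 9360 nM. Compound 2 is reported only as a limit, > 10000 nM. Both numbers sit close to the limit of > 10000 nM in this assay, at which 1 of the 3 values shown sits.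

The next compound is compound 4 `COc1ccc(C(=O)/C=C/c2cccc(O)c2)c2c1C=CC(C)(C)O2`, with 3-hydroxyphenyl in place of pyridin-2-yl on a double-bonded chain carbon bound to a double-bonded chain carbon.

Two measured steps change the same place. One is a 1.1-fold lower number from compound 1 to compound 3 (0.05 log units; within the scatter), which swaps 3-methoxyphenyl for pyridin-2-yl. The other is an at least 1.1-fold lower number from compound 2 to compound 3 (0.07 log units; that floor lies within the scatter), which swaps phenyl for pyridin-2-yl. A third, an at least 1.0-fold higher number from compound 1 to compound 2 (0.02 log units; that floor lies within the scatter), removes the methoxy from the 3-methoxyphenyl group. None of the three moves beyond the scatter, although two of them rest on a limit. Within the data shown here, no measured compound carries 3-hydroxyphenyl, so the hydroxyl itself is untested here.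

On these steps, no change beyond the scatter is expected in this assay. The expected step is a 1.0-fold lower number from compound 3 to compound 4 (0.02 log units; within the scatter). The estimated value for compound 4 is 8000 nM, within an expected range from 3500 nM to 14000 nM.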

Compound 4, half-maximal inhibitory concentration: > 10000 nM
Compound 4: only a limit was reported; the forecaster's own chance of this, stated with the estimate: 35%; middle value at least 1.2-fold (0.09 log units) from the limit.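

In this assay, compound 4 is reported only as a limit, > 10000 nM, and not as a number. 3-hydroxyphenyl, which brings a hydrogen-bond donor to a place where pyridin-2-yl has none, gives no readable step beyond the scatter on a double-bonded chain carbon bound to a double-bonded chain carbon: the readings are an at least 1.1-fold higher number from compound 3 to compound 4 (0.07 log units; that floor lies within the scatter), and, for hydrogen in place of methyl on an oxygen on an aromatic ring, an at least 1.0-fold higher number from compound 1 to compound 4 (0.02 log units; that floor lies within the scatter). The step between compound 2 and compound 4 cannot be read, and the series now gathers at the limit: the limit of > 10000 nM in this assay, at which 2 of the 4 values shown sit.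

As far as these compounds go, the true size of both readable steps stays open, as each is only a floor, so a larger loss from the hydroxyl cannot be ruled out. Also open, from the compounds shown here alone, is whether any group at this place can move the number beyond the scatter, for example a phenyl ring carrying an amine or a carboxylic acid.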